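Sultam-to-imide exchange on the benzylic carbon: cytotoxicity outlook

The source may hold more compounds than are shown below. What is called first, only, known or untested is meant among the compounds shown, and "the series" means these compounds.

Measured compounds
- compound 1 `CC1=C(c2ccc3ccccc3c2)S(=O)(=O)N(Cc2ccc(C(=O)N3CCCCC3)cc2)C1=O`, 47900 nM
- compound 2 `CC(C)(C)OC(=O)N(Cc1ccco1)C(=O)c1ccc(CN2Cc3ccccc3S2(=O)=O)cc1`, > 100000 nM
- compound 3 `O=C(NCc1ccco1)c1ccc(CN2Cc3ccccc3S2(=O)=O)cc1`, > 100000 nM

Going by the values given here, in an ADME assay on RAW264.7 cells (Mus musculus) for cytotoxicity, read by WST assay (a lower number here means that less compound is tolerated, a higher number that more compound is tolerated), compound 1 gives 47900 nM, the only numerical value in the set. Compound 2 reaches only a limit of this assay, > 100000 nM. Compound 3 likewise gives only a limit, > 100000 nM. Among the compounds with values here, the single change between them, hydrogen in place of tert-butoxycarbonyl on an amide-type nitrogen, gives a step that the two limits leave unreadable from compound 2 to compound 3, which cannot be sized since both values sit at the limit of > 100000 nM in this assay, at which 2 of the 3 values shown sit. Compound 2 therefore stands at the top of the measurable range, with nothing in this assay distinguishing it from compound 3.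

Compound 4 `CC(C)(C)OC(=O)N(Cc1ccco1)C(=O)c1ccc(CN2C(=O)c3ccccc3C2=O)cc1` differs from compound 2 by a group of 11 heavy atoms (8 carbon, 1 nitrogen, 2 oxygen; one five-membered non-aromatic ring with 1 hetero atom, one six-membered aromatic ring of carbon only) in place of a group of 11 heavy atoms (7 carbon, 1 nitrogen, 2 oxygen, 1 sulfur; one five-membered non-aromatic ring with 2 hetero atoms, one six-membered aromatic ring of carbon only), on a saturated chain carbon bound to an aromatic carbon. Within the data shown here, no measured step covers this exchange, and the one step available is unreadable, so nothing in this assay points in either direction. Compound 2 already sits at the limit, and compound 4 is expected to stay near it, with a number no higher from compound 2 to compound 4 (the limit leaves the size open) as the expected step, not beyond scatter. The estimate for compound 4 in this assay is 100000 nM, with a range from 40000 nM to 250000 nM.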

Compound 4, concentration lethal to 50% of the cells: > 100000 nM
Compound 4 ended at the assay's limit; the forecaster's own chance of this, stated with the estimate: 60%; the middle value sits exactly at the limit.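

Compound 2 and compound 4 both sit at a limit in this assay, and no step between them can be read: the limit of > 100000 nM in this assay, at which 3 of the 4 values shown sit.

The compounds shown leave open whether exchanging these two groups, on a saturated chain carbon bound to an aromatic carbon, alters tolerance at all beyond that limit.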